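Cyclohexyl replaces benzyl: expected cytotoxicity of compound 3

The source may report more compounds than this note shows. Statements on the series, on what has been measured and on what is new or still open speak of the compounds shown alone.

Compound 1 `O=[N+]([O-])c1cc(C[S+]([O-])c2nnnn2C2CCCCC2)cc([N+](=O)[O-])c1` and compound 2 `O=[N+]([O-])c1cc(C[Se]c2nnnn2Cc2ccccc2)cc([N+](=O)[O-])c1` were both tested in an ADME assay on Huh-7 cells (Homo sapiens) for cytotoxicity, read by MTT assay, with a stated time of 48 h; on this read-out higher numbers stand for weaker inhibition and lower numbers for stronger inhibition. For compound 1 the result is a limit of the assay, > 30000 nM. For compound 2 the result is likewise a limit, > 30000 nM. Compound 2 thus stands at the limit of > 30000 nM in this assay, at which 2 of the 2 values shown sit, where every measured value stands. Compound 3 `O=[N+]([O-])c1cc(C[Se]c2nnnn2C2CCCCC2)cc([N+](=O)[O-])c1` differs from compound 2 by cyclohexyl in place of benzyl on an aromatic nitrogen. Among the measured compounds shown here, no measured step between two compounds exists here, so in this assay the expected step is a step that the limit leaves unreadable from compound 2 to compound 3, none beyond the scatter. Compound 3 is therefore estimated at 40000 nM, between 20000 nM and 100000 nM, and is expected to give again only a limit.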

Compound 3, half-maximal inhibitory concentration: > 30000 nM
Compound 3 ended at the assay's limit; the forecaster's own chance of this, stated with the estimate: 80%; the middle value does not contradict the limit.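

Among the compounds shown here, compound 2 and compound 3 both sit at a limit of this assay, so no step from one to the other can be read. The compounds shown leave open whether cyclohexyl in place of benzyl on an aromatic nitrogen alters cytotoxicity at all.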